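The source may report more compounds than this note shows. Statements on the series, on what has been measured and on what is new or still open speak of the compounds shown alone.

Among the measured compounds shown here, in a functional assay, with a stated time of 6 min (a lower number here means a stronger inhibitor, a higher number a weaker inhibitor), compound 1 `S=c1oc(-c2ccc3c(c2)OCCO3)nn1CNc1ccccc1` gives 5140 nM and compound 2 `Fc1cccc(F)c1NCn1nc(-c2ccc3c(c2)OCCO3)oc1=S` gives 3320 nM with the two values inside the scatter of each other, so compound 2 stands level with compound 1 on the numbers so far. Next in the series is compound 3 `S=c1oc(-c2ccc3c(c2)OCCO3)nn1CNc1cccc(Cl)c1` with the difference 3-chlorophenyl in place of 2,6-difluorophenyl on an amine nitrogen at the same place, that is, 3-chlorophenyl in place of 2,6-difluorophenyl on an amine nitrogen. For the measured compounds named here, only one measured step bears on this change, and no measured compound carries 3-chlorophenyl. Since a 1.5-fold lower number from compound 1 to compound 2 (0.19 log units; within the scatter) stays within the scatter, no step beyond the scatter is expected in this assay in either direction. The estimate means a 1.2-fold higher number from compound 2 to compound 3 (0.08 log units; within the scatter) as the expected change. Compound 3 is expected at about 4000 nM with an estimated range from 1600 nM to 10000 nM in this read-out.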

Compound 3, half-maximal inhibitory concentration: 6220 nM
Compound 3: middle estimate off by 1.6-fold (0.19 log units), on the low side, within the range that was stated.
By their numbers in this assay, from the lowest: compounds 2, 1 and 3 (each within the scatter of the next).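

In this assay, chloro in place of hydrogen on an aromatic carbon gives a 1.2-fold higher number from compound 1 to compound 3 (0.08 log units; within the scatter), and 3-chlorophenyl in place of 2,6-difluorophenyl on the amine nitrogen gives a 1.9-fold higher number from compound 2 to compound 3 (0.27 log units; within the scatter), so both steps stay within the scatter. Phenyl, 2,6-difluorophenyl and 3-chlorophenyl at this place therefore cannot be told apart on these numbers, and neither fluorine nor chlorine on the ring separates from the unsubstituted phenyl. Nothing measured here offers an explanation for these values.

Still open, from the compounds shown here alone, is whether any group on this amine nitrogen gives a step beyond the scatter, for example a phenyl carrying methoxy or a carboxylic acid, a pyridine ring, or a saturated chain such as cyclohexyl. Going by these compounds, whether 4-chlorophenyl reads the same as 3-chlorophenyl also remains open.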